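This account rests on a few compounds, and the source may have more. Where it says the series, first, only, none or still open, it means among the compounds named here.

Measured so far:
Compound 1 `COc1cc(-c2ncnn2-c2ccc([N+](=O)[O-])cc2)cc(OC)c1OC` gives > 10000 nM in a functional assay on HL-60 cells (Homo sapiens) for antiproliferative activity, read by MTT assay, with a stated time of 72 h (a higher number here means a weaker inhibitor, a lower number a stronger inhibitor), which is a limit of the assay and not a number.
Compound 2 `COc1cc(-c2ncnn2-c2ccccc2)cc(OC)c1OC` gives > 10000 nM in this assay, likewise a limit.
Compound 3 `COc1cc(-n2ncnc2-c2ccccc2)cc(OC)c1OC` gives > 10000 nM in this assay, again a limit.

The change from compound 2 to compound 1 is nitro in place of hydrogen on an aromatic carbon. The step it made, a step that the two limits leave unreadable from compound 2 to compound 1, cannot be sized, since (the limit of > 10000 nM in this assay, at which 3 of the 3 values shown sit). Compounds 2 and 3 have the same atoms joined differently; the difference between the two cores is not broken down here. Compound 4 `COc1cc(-n2ncnc2-c2cccc([N+](=O)[O-])c2)cc(OC)c1OC` differs from compound 3 by nitro in place of hydrogen on an aromatic carbon. Around the place, the nitro group sits meta to a large group here but para to a large group in compound 1, so this is the same kind of change, not the same. The expected step that the limit leaves unreadable from compound 3 to compound 4 stands beside a step that the two limits leave unreadable from compound 2 to compound 1. That expectation rests on compound 3, which gives > 10000 nM, a limit, and on (the limit of > 10000 nM in this assay, at which 3 of the 3 values shown sit). Compound 4 is therefore estimated at 15000 nM in this assay, most likely reported again only as a limit.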

Compound 4, half-maximal inhibitory concentration: > 10000 nM
Compound 4 was reported as a limit; the forecaster's own chance of this, stated with the estimate: 80%; the middle value lies beyond the limit too.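

No new step can be read, as compound 3 and compound 4 are both reported only as limits, so the size of the change between them cannot be read: the limit of > 10000 nM in this assay, at which 4 of the 4 values shown sit.
The compounds shown leave open how strongly any of them acts in this assay and whether nitro in place of hydrogen alters that.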